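Removing One Chloro From the Shared Core

The source may hold more compounds than are shown below. What is called first, only, known or untested is meant among the compounds shown, and "the series" means these compounds.

Of the compounds shown here, two have so far been measured in a functional assay on OVCAR-5 cells (Homo sapiens) for cytotoxicity, read by sulforhodamine B assay, with a stated time of 48 h; a lower number here means that less compound is tolerated, a higher number that more compound is tolerated. Compound 1 `ClCc1ccccc1Cn1cnc2c(Cl)ncnc21` carries a single chloro on the shared core, and in this assay compound 1 gives 25700 nM. Compound 2 `ClCc1ccc(Cn2cnc3nc(Cl)nc(Cl)c32)cc1` carries two chloro groups on the same core, and in this assay compound 2 gives 8310 nM. That is the lowest of the two numbers; compound 1 stands above it by a gap beyond the usual scatter, so compound 2 is the more cytotoxic of the pair.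

Compound 3 `ClCc1ccc(Cn2cnc3ncnc(Cl)c32)cc1` differs from compound 2 in one place only: hydrogen in place of chloro on an aromatic carbon. Within the data shown here, no measured pair shows this exact change, and compound 1 and compound 2 differ in more than this one place, so their gap does not isolate the chloro. Without a direct precedent, a modest loss of cytotoxicity is the cautious expectation. The step is expected to be a 1.4-fold higher number from compound 2 to compound 3 (0.16 log units; within the scatter), a rise that may or may not clear the scatter. Compound 3 is therefore estimated at 12000 nM, with a plausible range from 5000 nM to 30000 nM.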

Compound 3, concentration lethal to 50% of the cells: 45700 nM
Estimate against measurement, compound 3: 3.8-fold (0.58 log units) below; measured number outside the range, above it.
By their numbers in this assay, from the lowest: compound 2; then compounds 1 and 3 (each within the scatter of the next).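

In this assay, among these compounds, replacing the chloro that sits between two ring nitrogen atoms with hydrogen gives a 5.5-fold higher number from compound 2 to compound 3 (0.74 log units; beyond the scatter) and provides the first comparison on the shared core in which only one place changes. It shows that this single chloro matters: with hydrogen in its place, more compound is tolerated, by a margin beyond the usual scatter, while the other chloro remains in both compounds. The data shown offer no measurement that explains this change, so the step stands as an observation without a known cause.

As far as these compounds go, only chloro and hydrogen have been compared at this position, so it remains open whether an amine, a methoxy group or a longer chain there would give a number close to that of compound 2, close to that of compound 3, or outside both. From the compounds shown here alone, the other chloro has no single-place comparison of its own, so the effect of replacing it with hydrogen or an amine also remains unknown.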